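Series notes: replacing the ethoxyphenyl arm of compound 2

This account rests on a few compounds, and the source may have more. Where it says the series, first, only, none or still open, it means among the compounds named here.

Measured so far:
compound 1 `COc1ccccc1-n1nc(C2CC(C)(C)OC(C)(C)C2)cc1-c1ccnc(Cl)c1`: 11 nM
compound 2 `CCOc1ccc(-c2cc(C3CC(C)(C)OC(C)(C)C3)nn2-c2ccccc2OC)cc1`: 2 nM

In an assay on HEK293 cells for inhibition of Voltage-dependent N-type calcium channel subunit alpha-1B (Homo sapiens), read by fluorescence and calcium flux, with a stated time of 5 min (on this read-out lower numbers stand for stronger inhibition and higher numbers for weaker inhibition), compound 1 gives 11 nM. Among the measured compounds shown here, compound 2 gives 2 nM, the lowest of the two numbers; the only other number, that of compound 1, lies a 5.5-fold lower number from compound 1 to compound 2 (0.74 log units; beyond the scatter) away, a modest step that does exceed the scatter. Compound 3 `COc1ccccc1-n1nc(C2CC(C)(C)OC(C)(C)C2)cc1-c1csc(Cl)c1` is still to be measured. It differs from compound 2 in one place: 5-chlorothiophen-3-yl in place of 4-ethoxyphenyl on an aromatic carbon. For the measured compounds named here, the single measured step that bears on this change is the one from compound 1 to compound 2, where 4-ethoxyphenyl took the place of 2-chloropyridin-4-yl at the same aromatic carbon and the number fell by a 5.5-fold lower number from compound 1 to compound 2 (0.74 log units; beyond the scatter). Compound 3 moves the other way, from 4-ethoxyphenyl back to a small chlorinated heteroaryl, 5-chlorothiophen-3-yl, so a step of roughly the size seen between compound 1 and compound 2, in the upward direction, is expected, a 4.0-fold higher number from compound 2 to compound 3 (0.60 log units; beyond the scatter). Going by the values given here, no measured step tells how a five-membered ring with one sulfur compares with the six-membered chloropyridine, so the range is kept wide. For compound 3 the estimate is 8 nM, with a range from 3 nM to 25 nM.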

Compound 3, half-maximal inhibitory concentration: 6 nM
Beside the measured number, compound 3's estimate is 1.3-fold (0.12 log units) above it; the range from low to high includes it.
By their numbers in this assay, from the lowest: compound 2; then compounds 3 and 1 (each within the scatter of the next).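

At this aromatic carbon, next to the ring nitrogen, the 4-ethoxyphenyl group of compound 2 now holds the lowest number against two different chlorinated heteroaryl groups: in this assay replacing it with 5-chlorothiophen-3-yl gives a 3.0-fold higher number from compound 2 to compound 3 (0.48 log units; beyond the scatter) as a modest step, so the earlier gain is not tied to 2-chloropyridin-4-yl alone as the comparison. The two chlorinated groups themselves are not told apart, with a 1.8-fold lower number from compound 1 to compound 3 (0.26 log units; within the scatter) as the step between them, so in this read-out a five-membered aromatic ring with one sulfur and the six-membered chloropyridine stand level at this carbon. Nothing available accounts for the difference between the 4-ethoxyphenyl group and the two chlorinated heteroaryl groups.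

The compounds shown do not separate the contribution of the ethoxy chain from that of the phenyl ring, nor that of the chlorine from that of the thiophene ring. As far as these compounds go, how an amine, a carboxylic acid or a longer alkoxy chain on the phenyl ring would read at this carbon stays open, as does whether these groups would rank the same with a different group in place of 2-methoxyphenyl.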